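Piperazine nitrogen substituent: aryl versus benzyl

The source may report more compounds than this note shows. Statements on the series, on what has been measured and on what is new or still open speak of the compounds shown alone.

Among the compounds with values here, compound 2 `Nc1ccccc1NC(=O)c1ccc(CSC(=S)N2CCN(Cc3ccccc3)CC2)cc1` stands at the low end of the two numbers measured so far. In a functional assay on A-375 cells (Homo sapiens) for antiproliferative activity, read by CCK-8 assay, with a stated time of 72 h, tested at 2 uM (a lower number here means a weaker effect, a higher number a stronger effect of the compound at the concentration tested), compound 2 gives 10.6%, while compound 1 `Nc1ccccc1NC(=O)c1ccc(CSC(=S)N2CCN(c3ccncc3)CC2)cc1` gives 85.7%. Within the data shown here, the single measured step, a number 75.1 percentage points lower from compound 1 to compound 2 (beyond the scatter), puts a six-membered aromatic ring bound directly to the amine nitrogen in a ring far above a benzyl group at the same place.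

Compound 3 `N#Cc1ccc(N2CCN(C(=S)SCc3ccc(C(=O)Nc4ccccc4N)cc3)CC2)cc1` carries the change (4-cyanophenyl in place of benzyl on an amine nitrogen in a ring). The step from compound 1 to compound 2 bears on it directly: both concern the group on the amine nitrogen in a ring, and the only aromatic ring bound straight to that nitrogen, in compound 1, gave the high reading. A step of similar size in the opposite direction is therefore expected, back upward, though the entering group is not the pyridin-4-yl of compound 1 and the two measured points give no further guide.

For compound 3 the expected step is a number 44.4 percentage points higher from compound 2 to compound 3 (beyond the scatter), and the estimate is 55% with a range of 20% to 85%.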

Compound 3, a percentage reported as inhibition, at one concentration (the size of the read-out at that concentration, not a potency): 41.4%
Beside the measured number, compound 3's estimate is 13.6 percentage points above it; the range from low to high includes it.
By their numbers in this assay, from the lowest: compound 2; then compound 3; then compound 1.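

In this assay, 4-cyanophenyl in place of benzyl on an amine nitrogen in a ring gives a number 30.8 percentage points higher from compound 2 to compound 3 (beyond the scatter), so a higher reading than benzyl's is not confined to pyridin-4-yl and also occurs with a six-membered aromatic ring of carbon only at this position. Direct attachment of an aromatic ring to this nitrogen does not by itself reproduce the reading of compound 1, however: 4-cyanophenyl in place of pyridin-4-yl gives a number 44.3 percentage points lower from compound 1 to compound 3 (beyond the scatter), which shows that the identity of the directly bound ring also matters here. No measurement on these compounds gives a reason for either step.

The compounds shown leave open how much of the gap between the two directly bound rings goes with the ring nitrogen of pyridin-4-yl and how much with the nitrile of 4-cyanophenyl, a question that a plain phenyl group at this position would help to separate. Also open, going by these compounds, is whether the high reading depends on where the ring nitrogen sits, which pyridin-3-yl or pyridin-2-yl at the same place would address.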